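A few compounds are considered here, and "the series" means these few. Any claim that something is new, unique, unknown or untested is made for them only; others in the source may bear on it.

Compound 1, `NS(=O)(=O)c1cccc(NC(=O)c2ccc(F)cc2)c1` — in an assay on isolated protein for inhibition of alkaline phosphatase, tissue-nonspecific isozyme (Bos taurus), read by chemiluminescence and spectrophotometry (a lower number here means a stronger inhibitor, a higher number a weaker inhibitor), compound 1 gives 16200 nM.
Compound 2, `Cc1ccc(S(=O)(=O)Nc2ccc(S(N)(=O)=O)cc2)cc1` — in this assay compound 2 gives 91900 nM.
Compound 3, `CCOc1ccc(NS(=O)(=O)c2ccc(F)cc2)cc1` — in this assay compound 3 gives "not determined" (no result reported).

Both measured compounds are weak inhibitors. For the measured compounds named here, compound 1 and compound 2 differ in more than one place, so no step is computed between them; their two values simply show that neither reaches strong inhibition. Going by the values given here, compound 3 stands on no number at all: its result was not determined, so there is no anchor for the step to compound 4.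

Compound 4, `CCOc1ccc(NS(=O)(=O)c2ccc(C)cc2)cc1`, differs from compound 3 by methyl in place of fluoro on an aromatic carbon. Among the compounds with values here, no measured pair shows this exchange, so its size and direction cannot be read from the data. The working expectation is for no step beyond the scatter in this assay, in either direction.

What can be used is the resemblance between compound 4 and compound 2, the closest measured compound in build; in this assay compound 2 gives 91900 nM. Compound 4 is therefore expected to remain a weak inhibitor, and the weak range also raises the chance that only a limit is reported.

For compound 4 the estimate in this assay is 60000 nM, with a range from 10000 nM to 300000 nM.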

Compound 4, inhibition constant: 128 nM
For compound 4 the middle estimate is 470-fold (2.67 log units) above the measured one; the whole stated range lies above it.
By their numbers in this assay, from the lowest: compound 4; then compound 1; then compound 2.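

In this assay, ethoxy in place of sulfamoyl on an aromatic carbon gives a 720-fold lower number from compound 2 to compound 4 (2.86 log units; beyond the scatter), and compound 4 reaches 128 nM, so this one exchange moves the series out of the weak range and a sulfamoyl group at this place is not needed for a value of that order. On these data alone, the methyl in place of fluoro, para to a large group, cannot be read as a step, since compound 3 has no number to stand against compound 4, and what the methyl itself contributes therefore stays unknown. No measurement at hand bears on why the ethoxy exchange has so large a step.

Still open, as far as these compounds go, is how much of the gain belongs to ethoxy as such, and whether a shorter group such as methoxy, a longer chain such as butoxy, or an amine or a carboxylic acid at that place would hold a value near that of compound 4. Also open, from the compounds shown here alone, is whether the methyl can give way to chloro or trifluoromethyl on the other aromatic ring without loss.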